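Notes on the step to compound 4

The source may hold more compounds than are shown below. What is called first, only, known or untested is meant among the compounds shown, and "the series" means these compounds.

Measured in an in vitro ADME assay on microsomes from liver (Simiiformes); a lower number here means that the compound disappears faster, a higher number that the compound lasts longer:
- compound 1 `CCOCc1cc(CCCOc2c(C)cc(-c3noc(C(F)(F)F)n3)cc2C)on1`: > 2.5 h
- compound 2 `COCc1cc(CCCOc2c(C)cc(-c3noc(C4CC4)n3)cc2C)on1`: > 2.5 h
- compound 3 `Cc1cc(CCCOc2c(C)cc(-c3noc(CC(F)(F)F)n3)cc2C)on1`: 0.533 h

Compound 1 stands at the limit of > 2.5 h in this assay, at which 2 of the 3 values shown sit; this is a limit of the assay, not a number. The value of compound 2 is also only a limit. Going by the values given here, compound 3 gives the one true number, 0.533 h.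

Compound 4 `Cc1cc(-c2noc(C(F)(F)F)n2)cc(C)c1OCCCc1cccc(F)n1` carries 6-fluoropyridin-2-yl in place of 3-(ethoxymethyl)-1,2-oxazol-5-yl on a saturated chain carbon, three bonds along the chain from an oxygen on an aromatic ring. Among the compounds with values here, no measured step covers this replacement, so the expectation is loose. A moderate fall is expected, since compound 3 at 0.533 h shows that shorter half-lives occur in this series. The expected change is an at least 1.2-fold lower number from compound 1 to compound 4 (0.09 log units; that floor lies within the scatter). For compound 4 the estimated half-life in this assay is 2 h, with an expected range of 0.6 h to 5 h.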

Compound 4, half-life: > 2.5 h
Compound 4: a limit, no number; the forecaster's own chance of this, stated with the estimate: 40%; middle value at least 1.2-fold (0.09 log units) away from the limit.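

No step can be read from compound 1 to compound 4, since both values are limits and not numbers: the limit of > 2.5 h in this assay, at which 3 of the 4 values shown sit.

On these data alone, how the half-lives of compound 1 and compound 4 compare, and so what replacing 3-(ethoxymethyl)-1,2-oxazol-5-yl with 6-fluoropyridin-2-yl does, stays open.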